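A few compounds are considered here, and "the series" means these few. Any claim that something is new, unique, unknown or untested is made for them only; others in the source may bear on it.

Working notes on the series. Compound 1 `CC1(C)[C@H]2CC[C@]1(C)N(Cc1cn(-c3cccc(Cl)c3)nn1)C(=O)C2`, compound 2 `CC1(C)[C@H]2CC[C@]1(C)N(Cc1cn(-c3ccccc3Br)nn1)C(=O)C2` and compound 3 `CC1(C)[C@H]2CC[C@]1(C)N(Cc1cn(-c3cccc(Br)c3)nn1)C(=O)C2` share one core and differ only in the group carried on the aromatic nitrogen. In a functional assay on LoVo cells (Homo sapiens) for inhibition, read by MTT assay, with a stated time of 24 h (a higher number here means a weaker inhibitor, a lower number a stronger inhibitor), compound 1 gives 70 nM, compound 2 gives 60 nM and compound 3 gives 30 nM. Compound 3 shows the lowest number of the three, but a 2.0-fold lower number from compound 2 to compound 3 (0.30 log units; within the scatter), and only a 2.3-fold lower number from compound 1 to compound 3 (0.37 log units; beyond the scatter) reaches beyond the scatter; a 1.2-fold lower number from compound 1 to compound 2 (0.07 log units; within the scatter) is small as well. Compound 4 `CC1(C)[C@H]2CC[C@]1(C)N(Cc1cn(-c3ccc(O)cc3)nn1)C(=O)C2` is not yet measured. It differs from compound 3 as follows: 4-hydroxyphenyl in place of 3-bromophenyl on an aromatic nitrogen. Going by the values given here, the three measured steps are the only precedent for changing the group on this nitrogen, and all are small; none of them brings in a hydrogen-bond donor or acceptor, and the data leave the direction for compound 4 open. For compound 4 a step of modest size, leaning toward a higher number, is expected, a 3.3-fold higher number from compound 3 to compound 4 (0.52 log units; beyond the scatter). Compound 4 is estimated at 100 nM in this assay, within a range of 30 nM to 400 nM.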

Compound 4, half-maximal inhibitory concentration: 410 nM
Estimate against measurement, compound 4: 4.1-fold (0.61 log units) below; the whole stated range lies below it.
By their numbers in this assay, from the lowest: compounds 3, 2 and 1 (each within the scatter of the next, the first and the last beyond it); then compound 4.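

In this assay the group on the aromatic nitrogen turns out to be able to move the number far beyond the scatter: there is a 14-fold higher number from compound 3 to compound 4 (1.14 log units; beyond the scatter) and, with the same sign, a 6.8-fold higher number from compound 2 to compound 4 (0.83 log units; beyond the scatter) and a 5.9-fold higher number from compound 1 to compound 4 (0.77 log units; beyond the scatter) for the other two compounds. The 3-chlorophenyl, 2-bromophenyl and 3-bromophenyl groups gave only small steps among themselves, so this position tolerates those groups but not every aryl group, and 4-hydroxyphenyl, which brings a hydrogen-bond donor and acceptor, stands apart from all three. No supporting measurement bears on the reason for this step.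

The compounds shown leave open whether the hydroxy group itself or its place on the phenyl ring carries the step. A methoxy group or an amine on that ring would begin to separate the two.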